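Azido in place of hydroxy: working notes

The compounds below may be only part of what the source reports. "The series", "measured", "known", "first", "only" and "open" are said of these compounds alone.

Measured so far in a functional assay on HCT-116 cells (Homo sapiens) for inhibition, read by MTT assay, with a stated time of 48 h; a lower number here means a stronger inhibitor, a higher number a weaker inhibitor:
compound 1 `C/C=C/C=C/C(=O)N(Cc1ccc(OC)c(O)c1)c1cc(OC)c(OC)c(OC)c1` at 180 nM
compound 2 `COc1ccc(CN(C(=O)CO)c2cc(OC)c(OC)c(OC)c2)cc1O` at 520 nM

Compound 2 at 520 nM holds the higher of the two numbers and is the weaker inhibitor of the pair. Awaiting measurement is compound 3 `COc1ccc(CN(C(=O)CN=[N+]=[N-])c2cc(OC)c(OC)c(OC)c2)cc1O` with the difference azido in place of hydroxy on a saturated chain carbon bound to a carbonyl carbon in the same part of the structure, azido in place of hydroxy on a saturated chain carbon bound to a carbonyl carbon. Among the compounds with values here, one measured step bears on this, the modest 2.9-fold higher number from compound 1 to compound 2 (0.46 log units; beyond the scatter) with hydroxymethyl in place of penta-1,3-dien-1-yl on a carbonyl carbon. Within the data shown here, no measured compound carries azido, so that step gives no direction and only a rough size. A step no larger than it is expected, and the expected step is a 1.3-fold lower number from compound 2 to compound 3 (0.11 log units; within the scatter) in this assay for now. Compound 3 is estimated at 400 nM with an expected range of 130 nM to 1300 nM at this stage.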

Compound 3, half-maximal inhibitory concentration: 410 nM
The estimate for compound 3 lay 1.0-fold (0.01 log units) below the measured number; low and high end bracket the measured number.
By their numbers in this assay, from the lowest: compound 1; then compounds 3 and 2 (each within the scatter of the next).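

In this assay azido in place of hydroxy on a saturated chain carbon bound to a carbonyl carbon gives a 1.3-fold lower number from compound 2 to compound 3 (0.10 log units; within the scatter) and so leaves the number within the scatter, even though 1 heavy atom leaves and 3 heavy atoms enter. Azidomethyl in place of penta-1,3-dien-1-yl on a carbonyl carbon gives a 2.3-fold higher number from compound 1 to compound 3 (0.36 log units; beyond the scatter) in this series, so the step away from penta-1,3-dien-1-yl stays beyond the scatter with azidomethyl as it did with hydroxymethyl. Nothing available explains either step.

On these data alone, whether an amine, a carboxylic acid or a longer chain on this saturated chain carbon would stay level with hydroxy and azido remains open. Also open, as far as these compounds go, is whether any such group would reach the number of compound 1 in this assay without the penta-1,3-dien-1-yl group.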